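Shortening an alkyne chain in a benzofuran aromatase series

The compounds below may be only part of what the source reports. "The series", "measured", "known", "first", "only" and "open" are said of these compounds alone.

Of the compounds shown here, three sharing one core have been tested in an assay on JEG-3 cells for inhibition of Aromatase (Homo sapiens), with a stated time of 1 h; a higher number here means a weaker inhibitor, a lower number a stronger inhibitor. Compound 1, `CC#CCOc1ccc2cc(C(c3ccc(Cl)cc3)n3cncn3)oc2c1`, gives 0.53 nM. Compound 2, `C#CCOc1ccc2cc(C(c3ccc(Cl)cc3)n3cncn3)oc2c1`, gives 1.03 nM. The change between them, (hydrogen in place of methyl on a triple-bonded carbon), produces a step of a 1.9-fold higher number from compound 1 to compound 2 (0.29 log units; within the scatter). Compound 3, `CCC#CCOc1ccc2cc(C(c3ccc(C#N)cc3)n3cncn3)oc2c1`, gives 0.72 nM; its value sits close to that of compound 1, and the difference between the two cores of compound 1 and compound 3 is not broken down here.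

Compound 4, `CC#CCOc1ccc2cc(C(c3ccc(C#N)cc3)n3cncn3)oc2c1`, has not yet been measured in this assay. Among the compounds with values here, it arises from compound 3 through (hydrogen in place of methyl on a saturated chain carbon bound to a triple-bonded carbon), which is the same kind of change as the one from compound 1 to compound 2, though not the same: there the methyl sat on a triple-bonded carbon whose other neighbour was a triple-bonded carbon, whereas here it sits on a saturated chain carbon bound to a triple-bonded carbon. Because compound 1 to compound 2 gave a 1.9-fold higher number from compound 1 to compound 2 (0.29 log units; within the scatter), a step of similar size is expected here, namely a 1.5-fold higher number from compound 3 to compound 4 (0.18 log units; within the scatter). On that basis compound 4 is estimated at 1.1 nM, expected within 0.5 nM to 2.4 nM.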

Compound 4, half-maximal inhibitory concentration: 0.09 nM
Compound 4: middle estimate off by 12-fold (1.09 log units), on the high side; the whole stated range lies above it.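

Shortening the alkyne chain by one carbon does not carry over as a fixed step between the two cores in this assay: the same change on two cores in this assay, a 1.9-fold higher number (0.29 log units; within the scatter) from compound 1 to compound 2 and an 8.0-fold lower number (0.90 log units; beyond the scatter) from compound 3 to compound 4, 16-fold (1.19 log units) apart, beyond the scatter of two such steps. On the core of compound 3, going from pent-2-yn-1-yl to but-2-yn-1-yl gives an 8.0-fold lower number from compound 3 to compound 4 (0.90 log units; beyond the scatter), whereas with the but-2-yn-1-yl chain held fixed, cyano in place of chloro on an aromatic carbon gives a 5.9-fold lower number from compound 1 to compound 4 (0.77 log units; beyond the scatter), so the effect of this chain change depends on the core it is made on. This rests on a single pair of compounds per core, and it shows neither why the two steps differ nor how the change would behave on any further core.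

The compounds shown leave open how a longer hex-2-yn-1-yl chain or a saturated butyl chain would read on either core. They also leave open whether a bromo group in place of chloro or cyano would give a step like the one seen on the core of compound 1 or the one seen on the core of compound 3.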